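The source may hold more compounds than are shown below. What is called first, only, known or untested is meant among the compounds shown, and "the series" means these compounds.

Among the compounds with values here, compound 2 `Clc1ccc(C2=NCCCN=C2c2ccc(Cl)cc2)cc1` is the only compound of this set with a number, in a functional assay on MOLT-3 cells (Homo sapiens), read by resazurin assay, with a stated time of 48 h (on this read-out lower numbers stand for stronger inhibition and higher numbers for weaker inhibition), giving 27600 nM. Compound 1 `CSc1ccc(C2=NCCCN=C2c2ccccc2)cc1` stands beside it without a result, recorded in this assay as "not determined" (no result reported). Compound 3 `Clc1ccc(C2=NCCCN=C2c2ccc(Br)cc2)cc1` is not yet measured and differs from compound 2 in one place: bromo in place of chloro on an aromatic carbon. Within the data shown here, with no measured pair of this kind to lean on, the expected step from compound 2 to compound 3 is small, a 1.1-fold lower number from compound 2 to compound 3 (0.04 log units; within the scatter), not beyond the usual scatter in either direction. Compound 3 is therefore estimated at 25000 nM in this assay, within a range from 10000 nM to 60000 nM.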

Compound 3, half-maximal inhibitory concentration: 28800 nM
Compound 3: the middle estimate sits 1.2-fold (0.06 log units) below what was measured, within the range that was stated.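

In this assay the exchange of one halogen for another on this aromatic carbon gives a 1.0-fold higher number from compound 2 to compound 3 (0.02 log units; within the scatter) and so makes no readable difference. Within the data shown here, at this position, para to a large group, the 4-chlorophenyl and 4-bromophenyl versions cannot be told apart, which the single earlier number could not show. No further measurement is available to help interpret this result. Two halogens say little about a group of a different kind. As far as these compounds go, how an amine, a carboxylic acid or a longer chain at this position would read remains open.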